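Chloro for fluoro on the extended chain of compound 2

A few compounds are considered here, and "the series" means these few. Any claim that something is new, unique, unknown or untested is made for them only; others in the source may bear on it.

In a functional assay on MIA PaCa-2 cells (Homo sapiens) for inhibition, read by MTT assay, with a stated time of 72 h (on this read-out lower numbers stand for stronger inhibition and higher numbers for weaker inhibition), compound 1 `COc1cc(NC(C)CCCNC(=O)Nc2cccc(Cl)c2)c2ncccc2c1` gives 21000 nM as its half-maximal inhibitory concentration. Compound 2 `COc1cc(NC(C)CCCNC(=O)NNC(=O)Nc2ccc(F)cc2)c2ncccc2c1` gives >= 250000 nM and this is a limit of the assay, not a number. Within the data shown here, the only measured step is an at least 11-fold higher number from compound 1 to compound 2 (1.07 log units; beyond the scatter) and it brings in ((4-fluorophenyl)carbamoyl)amino in place of 3-chlorophenyl on an amide-type nitrogen. Compound 3 `COc1cc(NC(C)CCCNC(=O)NNC(=O)Nc2ccc(Cl)cc2)c2ncccc2c1` keeps that extended chain and differs from compound 2 by chloro in place of fluoro on an aromatic carbon on an aromatic carbon, para to a large group. Among the measured compounds shown here, no measured step covers this exchange of chloro for fluoro, and the earlier step bears on it only indirectly. Given so small a change, a modest move toward a lower number is expected, estimated as an at least 1.6-fold lower number from compound 2 to compound 3 (0.22 log units; that floor lies within the scatter) and possibly ending at the same limit. In this assay compound 3 is expected at 150000 nM with 50000 nM to 300000 nM as the estimated range.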

Compound 3, half-maximal inhibitory concentration: >= 250000 nM
Compound 3 ended at the assay's limit (the forecaster's own chance of this, stated with the estimate: 50%); middle value at least 1.6-fold (0.22 log units) away from the limit.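

In this assay compound 3 gives >= 250000 nM, which is a limit of the assay and not a number. With chloro in place of fluoro, the extended chain still stands well apart from the 3-chlorophenyl urea of compound 1, with an at least 11-fold higher number from compound 1 to compound 3 (1.07 log units; beyond the scatter), so the large step seen earlier is not confined to the 4-fluorophenyl compound. Both ends of the exchange of chloro for fluoro are limits, so that step cannot be read and the two halogens cannot be ordered at this position: the limit of >= 250000 nM in this assay, at which 2 of the 3 values shown sit.

Going by these compounds, how far either compound lies beyond the limit stays open, and so does any real difference between them. Also open, on these data alone, is whether a methoxy group or an amine at this place on the ring would bring the extended chain back to a readable number.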